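The compounds below may be only part of what the source reports. "The series", "measured", "known", "first", "only" and "open" are said of these compounds alone.

- compound 1 `CC1=C(c2cccc(S(C)(=O)=O)c2)C(c2ccc(OC[C@H](C)N3CC[C@@H](C)C3)cc2)Oc2ccc(O)cc21` gives 4.3 nM
- compound 2 `CC1=C(c2cccc(O)c2)C(c2ccc(OC[C@H](C)N3CC[C@@H](C)C3)cc2)Oc2ccc(O)cc21` gives 0.2 nM

In a functional assay on MCF7 cells (Homo sapiens) for antiproliferative activity, read by CellTiter-Glo, with a stated time of 5 days (on this read-out higher numbers stand for weaker inhibition and lower numbers for stronger inhibition), compound 2 holds the lowest number of the two, at 0.2 nM. The gap to compound 1 lies beyond the scatter. Compound 3 `CC1=C(c2ccccc2)C(c2ccc(OC[C@H](C)N3CC[C@@H](C)C3)cc2)Oc2ccc(O)cc21` has hydrogen in place of hydroxy on an aromatic carbon so that 3-hydroxyphenyl becomes phenyl. Among the measured compounds shown here, one measured step bears on this carbon, the large 22-fold lower number from compound 1 to compound 2 (1.33 log units; beyond the scatter) on gaining hydroxy in place of methylsulfonyl. Losing the hydroxy is therefore expected to raise the number by a somewhat smaller amount, an estimated 7.5-fold higher number from compound 2 to compound 3 (0.88 log units; beyond the scatter) in this direction. Compound 3 is estimated at 1.5 nM with an expected range from 0.4 nM to 6 nM in this assay here.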

Compound 3, half-maximal inhibitory concentration: 0.4 nM
For compound 3 the middle estimate is 3.8-fold (0.57 log units) above the measured one, within the range that was stated.
By their numbers in this assay, from the lowest: compounds 2 and 3 (each within the scatter of the next); then compound 1.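

In this assay the hydroxy of the 3-hydroxyphenyl group can be replaced by hydrogen with a 2.0-fold higher number from compound 2 to compound 3 (0.30 log units; within the scatter) as the result, so the compounds shown give no sign that this hydroxy is needed. Hydrogen in place of methylsulfonyl gives an 11-fold lower number from compound 1 to compound 3 (1.03 log units; beyond the scatter) as its step, which places the large gap on the methylsulfonyl side of the series rather than on the hydroxy. Nothing available explains why methylsulfonyl stands apart from hydroxy and hydrogen. Still open, on these data alone, is whether a methoxy group, an amine or a carboxylic acid at this carbon would track hydrogen or methylsulfonyl.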